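The source may report more compounds than this note shows. Statements on the series, on what has been measured and on what is new or still open speak of the compounds shown alone.

In a functional assay on HeLa cells (Homo sapiens) for cytotoxicity (on this read-out lower numbers stand for stronger inhibition and higher numbers for weaker inhibition), compound 1 (`O=C(OC1=CC(=O)c2ccccc2C1=O)c1ccccc1`) gives 55000 nM and compound 2 (`CCCCOC1=CC(=O)c2ccccc2C1=O`) gives 35300 nM, and these two numbers lie within the usual scatter of each other. For the measured compounds named here, compound 2 therefore cannot be separated from compound 1 on the numbers so far. The next compound to consider is compound 3 (`CC(=O)OC1=CC(=O)c2ccccc2C1=O`), which departs from compound 2 in one place. The counted difference is acetyl in place of butyl on an oxygen on an unsaturated carbon and in words this is acetyl in place of butyl on an oxygen on an unsaturated carbon, so butoxy becomes acetoxy. Going by the values given here, no measured pair of compounds differing in one place is available as a guide, which leaves the size of this step uncertain. Among the compounds with values here, the one hint comes from compound 1, which resembles compound 3 in having a carbonyl on that oxygen. Compound 1 gives 55000 nM and that value sits within the scatter of compound 2, so no clear change in either direction is expected. The estimated step, a 1.1-fold higher number from compound 2 to compound 3 (0.05 log units; within the scatter) as expected here, stays within the scatter. The estimate for compound 3 is 40000 nM and it is expected to fall between 15000 nM and 100000 nM on repeated measurement.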

Compound 3, half-maximal inhibitory concentration: 62100 nM
Compound 3: the middle estimate sits 1.6-fold (0.19 log units) below what was measured; low and high end bracket the measured number.
By their numbers in this assay, from the lowest: compounds 2, 1 and 3 (each within the scatter of the next).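

In this assay, the change from butoxy to acetoxy gives a 1.8-fold higher number from compound 2 to compound 3 (0.25 log units; within the scatter), so this first single-place change on the oxygen on an unsaturated carbon does not separate acetyl from butyl, even though acetyl brings a carbonyl that butyl lacks. The second change, methyl in place of phenyl on a carbonyl carbon, gives a 1.1-fold higher number from compound 1 to compound 3 (0.05 log units; within the scatter), which shows that on this carbonyl carbon the loss of the phenyl ring also leaves no change that can be told from the scatter. No independent measurement bears on these results.

The compounds shown leave open whether any group on this oxygen can move the number beyond the scatter, for instance a chain longer than butyl, or an acyl group that carries an amine or a carboxylic acid. Also open, from the compounds shown here alone, is whether a bare hydroxyl on the unsaturated carbon, or a phenyl bearing a chlorine or a methoxy group on the carbonyl carbon, would stand apart from these three compounds.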